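Aryl methoxy to trifluoromethyl on the ketone core

This account rests on a few compounds, and the source may have more. Where it says the series, first, only, none or still open, it means among the compounds named here.

Compound 1 `COc1ccc(-c2noc(CCCCCCC(=O)NO)n2)cc1` and compound 2 `O=C(CCCCCCc1nc(-c2ccc(C(F)(F)F)cc2)no1)NO` share one core; compound 3 `COc1ccc(-c2noc(CCCCCCC(=O)C(F)(F)F)n2)cc1` and compound 4 `O=C(CCCCCCc1nc(-c2ccc(C(F)(F)F)cc2)no1)C(F)(F)F` share another. The two cores differ by trifluoromethyl in place of hydroxyamino on a carbonyl carbon, which gives a step of an at least 5.3-fold lower number from compound 1 to compound 3 (0.73 log units; beyond the scatter). In an assay on isolated protein for inhibition of histone deacetylase 8 (Homo sapiens), read by fluorescence, with a stated time of 10 min (on this read-out lower numbers stand for stronger inhibition and higher numbers for weaker inhibition), compound 1 gives only a limit, > 10000 nM. Compound 2 also gives only a limit, > 10000 nM. Compound 3 gives 1860 nM. The change from compound 1 to compound 2 is trifluoromethyl in place of methoxy on an aromatic carbon, and its step, a step that the two limits leave unreadable from compound 1 to compound 2, is hidden by the limit of > 10000 nM in this assay, at which 2 of the 3 values shown sit. The same change recurs as trifluoromethyl in place of methoxy on an aromatic carbon. There is thus no readable precedent for it; the expectation rests on compound 3 alone, at 1860 nM. A step of a 1.3-fold higher number from compound 3 to compound 4 (0.13 log units; within the scatter) is expected. Compound 4 is estimated at 2500 nM, with a range from 800 nM to 8000 nM.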

Compound 4, half-maximal inhibitory concentration: 1030 nM
Compound 4: the middle estimate sits 2.4-fold (0.39 log units) above what was measured; measured number inside the range.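

On the ketone core, trifluoromethyl in place of methoxy on the aromatic carbon gives a 1.8-fold lower number from compound 3 to compound 4 (0.26 log units; within the scatter), so in this assay this change has no readable effect there. Trifluoromethyl in place of hydroxyamino on a carbonyl carbon now gives an at least 9.7-fold lower number from compound 2 to compound 4 (0.98 log units; beyond the scatter), the same direction on both cores, though the sizes cannot be compared: the same change on two cores in this assay, an at least 5.3-fold lower number (0.73 log units; beyond the scatter) from compound 1 to compound 3 and an at least 9.7-fold lower number (0.98 log units; beyond the scatter) from compound 2 to compound 4; the limit leaves it open whether they differ. From the compounds shown here alone, the methoxy change on the hydroxyamino core cannot be read, so carrying it between cores remains untested, and the assay limit stands in the way: the limit of > 10000 nM in this assay, at which 2 of the 4 values shown sit.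

Open, going by these compounds, is whether an amine or a carboxylic acid in that aromatic position would move the ketone series beyond the scatter. On these data alone, a longer chain before the carbonyl also remains open.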